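Replacing the 4,4-difluorocyclohexyl Group of Compound 2

The source may hold more compounds than are shown below. What is called first, only, known or untested is meant among the compounds shown, and "the series" means these compounds.

Going by the values given here, only two compounds have been measured so far. In an ADME assay on microsomes from liver (Mus musculus) for metabolic stability, using NADPH, with a stated time of 10 min (a higher number here means that more of the compound is left, a lower number that less of the compound is left), compound 1 `CN(C[C@H]1Cc2ncccc2CN1)[C@H]1CCCc2cccnc21` gives 53% of the parent left, and compound 2 `CN(CCCCN(C[C@H]1Cc2ncccc2CN1)[C@H]1CCCc2cccnc21)C1CCC(F)(F)CC1` gives 35% under the same conditions. Compound 2 therefore holds the lower of the two numbers, and its gap to compound 1 lies beyond the usual scatter.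

The next compound, compound 3 `CN(CCCCN(C[C@H]1Cc2ncccc2CN1)[C@H]1CCCc2cccnc21)C1CCOCC1`, has not yet been measured. It differs from compound 2 in one place: oxan-4-yl in place of 4,4-difluorocyclohexyl on an amine nitrogen with oxan-4-yl in place of 4,4-difluorocyclohexyl on an amine nitrogen. Among the compounds with values here, no measured pair isolates this exchange, so the data offer only indirect guidance. Within the data shown here, the one hint is that compound 1 at 53% lacks the whole substituent that holds this ring, and that is weak evidence. The step expected in this assay is a number 8 percentage points higher from compound 2 to compound 3 (within the scatter) in the upward direction, of modest size and probably within the scatter. Compound 3 is estimated at 43% with an expected range from 28% to 60% for this read-out.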

Compound 3, percent of the compound remaining: 51%
Estimate against measurement, compound 3: 8 percentage points below, and the stated range covers the measured number.
By their numbers in this assay, from the lowest: compound 2; then compounds 3 and 1 (each within the scatter of the next).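

In this assay, oxan-4-yl in place of 4,4-difluorocyclohexyl on an amine nitrogen gives a number 16 percentage points higher from compound 2 to compound 3 (beyond the scatter) and so provides the only exchange shown here that is confined to this ring, on a nitrogen whose other neighbours are saturated chain carbons; the read-out responds to what this ring carries. The comparison with the smaller compound gives a number 2 percentage points lower from compound 1 to compound 3 (within the scatter) for a group of 11 heavy atoms in place of a hydrogen atom, on a saturated chain carbon bound to an amine nitrogen, so with oxan-4-yl at its end the whole substituent leaves no difference that can be read in this assay. No measurement shown here explains the step between the two rings.

The two compounds with a ring at this position leave open whether the step follows the ring oxygen, the two fluorine atoms that leave, or both, and a plain cyclohexyl or a piperidin-4-yl group would help to separate these. Also open, as far as these compounds go, is how the read-out responds to a shorter or longer chain leading to this amine nitrogen.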